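The source may report more compounds than this note shows. Statements on the series, on what has been measured and on what is new or still open speak of the compounds shown alone.

Measured compounds:

Compound 1 `O=C1COc2ccc(-c3cnc(Cl)c(NS(=O)(=O)c4ccc(F)cc4)c3)cc2N1c1ccc(F)cc1`: in a functional assay on MCF7 cells (Homo sapiens) for antiproliferative activity, read by MTT assay, with a stated time of 72 h (on this read-out lower numbers stand for stronger inhibition and higher numbers for weaker inhibition), compound 1 gives 32600 nM.
Compound 2 `O=C1COc2ccc(-c3cnc(Cl)c(NS(=O)(=O)c4ccc(F)cc4)c3)cc2N1C1CCCCC1`: in this assay compound 2 reaches only a limit of the assay, > 40000 nM.
Compound 3 `O=C1COc2ccc(-c3cnc(Cl)c(NS(=O)(=O)c4ccc(F)cc4)c3)cc2N1c1ccc(Cl)cc1`: in this assay compound 3 gives 32800 nM.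

Compound 3 holds the highest of the two numbers given, but the step of a 1.0-fold higher number from compound 1 to compound 3 (0.00 log units; within the scatter) lies within the scatter, so compound 1 and compound 3 cannot be told apart. Compound 4 `CC(C)N1C(=O)COc2ccc(-c3cnc(Cl)c(NS(=O)(=O)c4ccc(F)cc4)c3)cc21` differs from compound 3 by isopropyl in place of 4-chlorophenyl on an amide-type nitrogen in a ring. For the measured compounds named here, two measured steps change the same position: an at least 1.2-fold higher number from compound 1 to compound 2 (0.08 log units; that floor lies within the scatter) and an at least 1.2-fold lower number from compound 2 to compound 3 (0.08 log units; that floor lies within the scatter), both resting on the limit (the limit of > 40000 nM in this assay, at which 1 of the 3 values shown sits), where the one compound carrying a non-aromatic group in this place gave no number at all. Compound 4 again carries a non-aromatic group there, so the expectation is a number no lower than that of compound 3, and most likely another limit. Compound 4 is therefore estimated at 45000 nM, with a range from 25000 nM to 80000 nM. The expected step is a 1.4-fold higher number from compound 3 to compound 4 (0.14 log units; within the scatter).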

Compound 4, half-maximal inhibitory concentration: 26600 nM
For compound 4 the middle estimate is 1.7-fold (0.23 log units) above the measured one, within the range that was stated.
By their numbers in this assay, from the lowest: compounds 4, 1 and 3 (each within the scatter of the next). At a limit, above all of these: compound 2.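

In this assay, a non-aromatic group on the amide-type nitrogen now gives a number, and it cannot be told apart from either aromatic group: a 1.2-fold lower number from compound 3 to compound 4 (0.09 log units; within the scatter) and a 1.2-fold lower number from compound 1 to compound 4 (0.09 log units; within the scatter). Isopropyl brings 3 heavy atoms and no ring where 4-chlorophenyl had 7 heavy atoms and an aromatic ring, yet this large change in the group leaves the number within the scatter. For the compounds shown here, compound 2, with cyclohexyl, remains the one compound at a limit: the limit of > 40000 nM in this assay, at which 1 of the 4 values shown sits. Measured against that limit, the step is only a floor: an at least 1.5-fold lower number from compound 2 to compound 4 (0.17 log units; that floor lies within the scatter).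

Whether any group at this position can move the number beyond the scatter stays open, since no readable step shown does so. A chain ending in an amine or a carboxylic acid on this nitrogen would put that question to a different kind of group.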